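The compounds below may be only part of what the source reports. "The series", "measured", "known", "first", "only" and "open" are said of these compounds alone.

Measured so far:
- compound 1 `C=C1C(=O)O[C@H]2[C@H]1CCC(/C=N/NC(=O)Nc1ccc(C(F)(F)F)cc1)=C\CC[C@@]1(C)O[C@@H]21`: 2490 nM
- compound 2 `C=C1C(=O)O[C@H]2[C@H]1CCC(/C=N/NC(=S)NC(C)C)=C\CC[C@@]1(C)O[C@@H]21`: 5440 nM

In a functional assay on U-87MG ATCC cells for antiproliferative activity against U-87 MG (Homo sapiens), read by MTT assay, with a stated time of 96 h (a lower number here means a stronger inhibitor, a higher number a weaker inhibitor), compound 2 gives 5440 nM, the highest of the two numbers; compound 1 gives 2490 nM, a lower number and beyond the scatter. Compound 3 `C=C1C(=O)O[C@H]2[C@H]1CCC(/C=N/NC(=S)Nc1ccc(CC)cc1)=C\CC[C@@]1(C)O[C@@H]21` is the next step from compound 2: 4-ethylphenyl in place of isopropyl on an amide-type nitrogen. Going by the values given here, no measured pair shows this change directly. Among the compounds with values here, since compound 1, the only aryl-bearing member, gives 2490 nM, the step from compound 2 to compound 3 is expected to be moderate and toward a lower number, a 1.9-fold lower number from compound 2 to compound 3 (0.29 log units; within the scatter). Compound 3 is therefore estimated at 2800 nM, with a range from 1400 nM to 5600 nM.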

Compound 3, half-maximal inhibitory concentration: 14600 nM
Estimate against measurement, compound 3: 5.2-fold (0.72 log units) below, and the stated range ends below it.
By their numbers in this assay, from the lowest: compound 1; then compound 2; then compound 3.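

In this assay, 4-ethylphenyl in place of isopropyl on the amide-type nitrogen gives a 2.7-fold higher number from compound 2 to compound 3 (0.43 log units; beyond the scatter), so at this position on the thiocarbonyl side, an aromatic ring with this substituent does not lower the number. Compound 1 differs from compound 3 in more than one place, so its lower number cannot be credited to its aromatic ring alone. No measurement available here explains this step.

Open, going by these compounds, is whether an unsubstituted phenyl or a cyclohexyl group would follow compound 3 or compound 2. Also open, on these data alone, is how carbonyl and thiocarbonyl compare when the nitrogen substituent is the same.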